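Propoxy for dipropylamino on the shared core

The source may hold more compounds than are shown below. What is called first, only, known or untested is meant among the compounds shown, and "the series" means these compounds.

Measured compounds:
compound 1 `CCCN(CCC)c1cc(C(F)(F)F)ccc1CNC(=O)C(C)c1ccc(NS(C)(=O)=O)c(F)c1`, 0.3 nM
compound 2 `CC(C(=O)NCc1ccc(C(F)(F)F)cc1N1CCN(C2CCCCC2)CC1)c1ccc(NS(C)(=O)=O)c(F)c1`, 13.8 nM
compound 3 `Cc1ccc(N2CCN(c3cc(C(F)(F)F)ccc3CNC(=O)C(C)c3ccc(NS(C)(=O)=O)c(F)c3)CC2)cc1`, 0.7 nM

All three were tested in an assay on CHO cells for antagonist activity at transient receptor potential cation channel subfamily V member 1 (Homo sapiens), read by FLIPR; on this read-out higher numbers stand for weaker inhibition and lower numbers for stronger inhibition. Compound 1 gives the lowest number of the three: compound 3 lies nearest to it, with 0.7 nM, and compound 2 lies furthest, with 13.8 nM. The two measured steps both concern the same aromatic carbon that the present step touches. From compound 1 to compound 2 the number rises sharply, a 46-fold higher number from compound 1 to compound 2 (1.66 log units; beyond the scatter), and from compound 2 to compound 3 it falls again, a 20-fold lower number from compound 2 to compound 3 (1.29 log units; beyond the scatter). Both steps show that what sits on this carbon matters a great deal in this assay, and that a wrong choice costs much more than the usual scatter.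

Compound 4 `CCCOc1cc(C(F)(F)F)ccc1CNC(=O)C(C)c1ccc(NS(C)(=O)=O)c(F)c1` is not yet measured. It differs from compound 1 in one place: propoxy in place of dipropylamino on an aromatic carbon. Within the data shown here, no measured pair shows propoxy at this position, so the direction can only be guessed from the strong sensitivity seen in compound 2 and compound 3. A moderate loss is expected: compound 4 is estimated at 1.2 nM, within 0.3 nM to 6 nM, which means an expected step of a 4.0-fold higher number from compound 1 to compound 4 (0.60 log units; beyond the scatter).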

Compound 4, inhibition constant: 2 nM
The estimate for compound 4 lay 1.7-fold (0.22 log units) below the measured number; the measured number falls inside the stated range.
By their numbers in this assay, from the lowest: compound 1; then compound 3; then compound 4; then compound 2.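

In this assay, among these compounds, the earlier compounds all carried a nitrogen on this aromatic carbon, and compound 4 shows that a low number survives when propoxy stands there instead, although the change still brings a 6.7-fold higher number from compound 1 to compound 4 (0.82 log units; beyond the scatter) and so costs more than the usual scatter. The same compound also sits well clear of the cyclohexylpiperazine analogue, with a 6.9-fold lower number from compound 2 to compound 4 (0.84 log units; beyond the scatter) in the reverse direction, so propoxy falls between dipropylamino and 4-cyclohexylpiperazin-1-yl on this read-out. No measurement on hand explains why propoxy ranks where it does on this carbon.

The change swaps nitrogen for oxygen and removes one propyl chain in a single move, so the compounds shown cannot say which of the two accounts for the rise in the number; a propylamino group, with its single chain on nitrogen, would separate them. On these data alone, how the number responds to chain length on the oxygen also stays open, and an ethoxy group or a butoxy chain on the same carbon would address that.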